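The source may hold more compounds than are shown below. What is called first, only, known or untested is meant among the compounds shown, and "the series" means these compounds.

In an assay on CHO cells for displacement of a labelled ligand from histamine receptor H3 (Macaca mulatta), read by scintillation counting, with a stated time of 1 h (a higher number here means a weaker inhibitor, a lower number a stronger inhibitor), compound 1, `O=C(Nc1ccc(OCCCN2CCCCC2)cc1)Nc1cc(Cl)cc(Cl)c1`, gives 3.4 nM, and compound 2, `Cc1c(Cl)cc(NC(=O)Nc2ccc(OCCCN3CCCCC3)cc2)cc1Cl`, gives 18.2 nM. Between them the change is methyl in place of hydrogen on an aromatic carbon, and it costs a 5.4-fold higher number from compound 1 to compound 2 (0.73 log units; beyond the scatter). Compound 3, `CC1CCCN1C1CCN(c2ccc(NC(=O)NCc3cc(Cl)cc(Cl)c3)cc2)C1`, gives 7.1 nM in this assay, standing between the two others, with a lower number than compound 2 and a higher number than compound 1; how the core of compound 3 differs from the core of compound 1 is not broken down here.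

Compound 4, `Cc1cc(NC(=O)NCc2cc(Cl)cc(Cl)c2)ccc1N1CCC(N2CCCC2C)C1`, has not yet been measured. It differs from compound 3 by methyl in place of hydrogen on an aromatic carbon. This is the same kind of change as that from compound 1 to compound 2, but not the same: there the methyl entered ortho to two chloro groups and para to a large group, whereas here it enters ortho to a large group and meta to a large group. Going by the values given here, since the only measured precedent for adding a methyl is the step of a 5.4-fold higher number from compound 1 to compound 2 (0.73 log units; beyond the scatter), compound 4 is expected to show a weaker version of that loss, a step of a 1.8-fold higher number from compound 3 to compound 4 (0.26 log units; within the scatter) in this assay. On that basis compound 4 is estimated at 13 nM, expected to fall between 4 nM and 40 nM.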

Compound 4, inhibition constant: 28.8 nM
Beside the measured number, compound 4's estimate is 2.2-fold (0.35 log units) below it; measured number inside the range.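

In this assay, methyl in place of hydrogen on an aromatic carbon again raises the number, here by a 4.1-fold higher number from compound 3 to compound 4 (0.61 log units; beyond the scatter), and the two steps match in size: the same change on two cores in this assay, a 5.4-fold higher number (0.73 log units; beyond the scatter) from compound 1 to compound 2 and a 4.1-fold higher number (0.61 log units; beyond the scatter) from compound 3 to compound 4, 1.3-fold (0.12 log units) apart, within the scatter of two such steps

On these two pairs, then, the loss carries over from one core to the other, even though the methyl does not stand in the same place on both; in compound 4 it is ortho to a large group and meta to a large group. Two pairs show neither why the methyl costs binding strength nor that the same loss would appear on any further core in this series.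

The compounds shown leave open whether an ethyl, a methoxy or a fluorine in place of that hydrogen would cost as much as the methyl. They also leave open what a methyl would do on the other carbons of the same aromatic ring.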